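This account rests on a few compounds, and the source may have more. Where it says the series, first, only, none or still open, it means among the compounds named here.

Measured so far in a functional assay on NCI-H322M cells (Homo sapiens) for inhibition, read by sulforhodamine B assay, with a stated time of 48 h; a lower number here means a stronger inhibitor of growth, a higher number a weaker inhibitor of growth:
- compound 2 `Nc1cc(N)c2nc(-c3ccccc3)c(NCc3ccc(Cl)c(Cl)c3)nc2c1`: 13500 nM
- compound 3 `CCOC(=O)[C@H](CCC(=O)O)NC(=O)c1ccc(Oc2nc3cc(N)cc(N)c3nc2-c2ccccc2)cc1`: 67600 nM
- compound 1 `CCOC(=O)[C@H](CCC(=O)O)NC(=O)c1ccc(CNc2nc3cc(N)cc(N)c3nc2-c2ccccc2)cc1`: in this assay compound 1 gives only a limit, < 100000 nM (the limit of < 100000 nM in this assay, at which 1 of the 3 values shown sits).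

Compound 2 stands lowest of the two numbers; the nearest, compound 3, gives a higher number, and that gap lies beyond the scatter. Compound 4 `COc1ccc(CNc2nc3cc(N)cc(N)c3nc2-c2ccccc2)cc1` differs from compound 2 in one place: 4-methoxyphenyl in place of 3,4-dichlorophenyl on a saturated chain carbon bound to a nitrogen on an aromatic ring. Within the data shown here, no step between measured compounds covers this change, so the direction rests on compound 2 alone. The expected step of a 2.2-fold higher number from compound 2 to compound 4 (0.35 log units; beyond the scatter) is modest, toward a higher number, and may not exceed the scatter. Compound 4 is estimated at 30000 nM, with a range from 8000 nM to 100000 nM.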

Compound 4, concentration for 50% growth inhibition: 22900 nM
Compound 4: the middle estimate sits 1.3-fold (0.12 log units) above what was measured, and the stated range covers the measured number.
By their numbers in this assay, from the lowest: compounds 2 and 4 (each within the scatter of the next); then compound 3.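

Among these compounds, the step of a 1.7-fold higher number from compound 2 to compound 4 (0.23 log units; within the scatter) in this assay is the first direct reading at this position. On the saturated chain carbon bound to a nitrogen on an aromatic ring, 4-methoxyphenyl and 3,4-dichlorophenyl cannot be told apart in growth inhibition, although one group carries two chlorine atoms and the other a hydrogen-bond acceptor. No available evidence bears on this step. Still open, going by these compounds, is how this position responds to groups outside the substituted phenyls, such as a pyridine ring or a cyclohexyl ring. On these data alone, a longer chain between the nitrogen and the ring also remains open.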